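Trimming a Side Group: What Size of Step to Expect

A few compounds are considered here, and "the series" means these few. Any claim that something is new, unique, unknown or untested is made for them only; others in the source may bear on it.

In a functional assay on NCI-H23 cells (Homo sapiens) for cytotoxicity, read by colorimetric assay (a higher number here means a weaker inhibitor, a lower number a stronger inhibitor), compound 1 `O=C(NO)c1ccc(CN2C(=O)/C(=C3\Nc4ccccc4\C3=N/O)c3cc(F)ccc32)cc1` gives 30 nM, compound 2 `Cc1ccc2c(c1)/C(=C1/Nc3ccccc3/C1=N\O)C(=O)N2Cc1ccc(C(=O)NO)cc1` gives 10 nM and compound 3 `O=C(/C=C/c1ccc(CN2C(=O)/C(=C3\Nc4ccccc4\C3=N/O)c3cc(Br)ccc32)cc1)NO` gives 9 nM. Compound 3 and compound 2 are level within the usual scatter, while the number for compound 1 lies clearly higher than both.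

The next molecule, compound 4 `O=C(NO)c1ccc(CN2C(=O)/C(=C3\Nc4ccccc4\C3=N/O)c3cc(Br)ccc32)cc1`, differs from compound 3 in one place: hydroxycarbamoyl in place of 2-(hydroxycarbamoyl)ethenyl on an aromatic carbon. In words, hydroxycarbamoyl stands in place of 2-(hydroxycarbamoyl)ethenyl on an aromatic carbon of a six-membered aromatic ring of carbon only, para to a large group.

Going by the values given here, no measured pair makes this exchange, so any forecast is indirect. Among the compounds with values here, the only measured step, a 3.0-fold lower number from compound 1 to compound 2 (0.48 log units; beyond the scatter), is a modest one that puts methyl in place of fluoro at a different site. It still matters, since compound 1 and compound 2 both carry hydroxycarbamoyl, as compound 4 does. Their values, compound 2 at 10 nM and compound 1 at 30 nM, suggest where such molecules can fall. A modest rise is therefore expected in this assay, with the estimated change being a 2.2-fold higher number from compound 3 to compound 4 (0.35 log units; beyond the scatter). The expected value for compound 4 is 20 nM, within an estimated range from 7 nM to 55 nM.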

Compound 4, half-maximal inhibitory concentration: 7 nM
For compound 4 the middle estimate is 2.9-fold (0.46 log units) above the measured one; the range from low to high includes it.
By their numbers in this assay, from the lowest: compounds 4, 3 and 2 (each within the scatter of the next); then compound 1.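

In this assay, putting hydroxycarbamoyl in place of 2-(hydroxycarbamoyl)ethenyl on an aromatic carbon, para to a large group, gives a 1.3-fold lower number from compound 3 to compound 4 (0.11 log units; within the scatter), so with bromo on the shared core the shorter group and the longer one leave the compounds level. The other two comparisons concern a different place, the aromatic carbon of the core that carries bromo, methyl or fluoro: a 1.4-fold lower number from compound 2 to compound 4 (0.15 log units; within the scatter) shows bromo and methyl level, whereas a 4.3-fold lower number from compound 1 to compound 4 (0.63 log units; beyond the scatter) separates bromo from fluoro, with a step that is modest but clearly real. No measurement available here accounts for any of these results.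

Going by these compounds, the side-group exchange has been read only with bromo on the core, so it remains open whether the shorter and longer groups would also be level with fluoro or methyl there. Also open, on these data alone, is how the number would respond to a carboxylic acid in place of hydroxycarbamoyl, or to a longer chain ending in hydroxycarbamoyl, at this same place.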